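Adenosine analogues with substituted benzyl groups: antiproliferative notes

The source may hold more compounds than are shown below. What is called first, only, known or untested is meant among the compounds shown, and "the series" means these compounds.

The series is built on a shared core in which a substituted benzyl group sits on the amine. Compound 1 `OC[C@H]1O[C@@H](n2cnc3c(NCc4cccc(F)c4)ncnc32)[C@H](O)[C@@H]1O` carries a fluorinated benzyl group, compound 2 `Cc1cccc(CNc2ncnc3c2ncn3[C@@H]2O[C@H](CO)[C@@H](O)[C@H]2O)c1` carries a methylbenzyl group, and compound 3 `Cc1ccc(CNc2ncnc3c2ncn3[C@@H]2O[C@H](CO)[C@@H](O)[C@H]2O)cc1` carries a 4-methylbenzyl group. In a functional assay on B16 cells (Mus musculus) for antiproliferative activity, with a stated time of 72 h (on this read-out higher numbers stand for weaker inhibition and lower numbers for stronger inhibition), compound 1 gives "not determined" (no result reported). In this assay compound 2 gives > 166000 nM, which is a limit of the assay and not a number. In this assay compound 3 gives "not determined" (no result reported).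

Compound 3 therefore has no single number to stand on: of the three entries in this assay, one further one is a limit and one further one is without a number. The only quantitative anchor for the whole series is the limit of > 166000 nM in this assay, at which 1 of the 3 values shown sits.

Compound 4 `OC[C@H]1O[C@@H](n2cnc3c(NCc4ccc(F)cc4F)ncnc32)[C@H](O)[C@@H]1O` differs from compound 3 by 2,4-difluorophenyl in place of 4-methylphenyl on a saturated chain carbon bound to a nitrogen on an aromatic ring. Among the compounds with values here, no step between measured compounds exists, so the size and direction of the change from compound 3 to compound 4 in this assay cannot be read from the series; any expectation rests on the single limit and is accordingly weak, with no step beyond the scatter assumed. Compound 4 is estimated to give about 100000 nM in this assay, expected to fall between 20000 nM and 300000 nM.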

Compound 4, half-maximal inhibitory concentration: > 166000 nM
Compound 4: no number, only a limit; the forecaster's own chance of this, stated with the estimate: 50%; middle value at least 1.6-fold (0.22 log units) away from the limit.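

In this assay compound 4 gives > 166000 nM as a limit of the assay and not a number. Within the data shown here, compound 2 also stands at a limit, so no step from compound 2 to compound 4 can be read: the limit of > 166000 nM in this assay, at which 2 of the 4 values shown sit.

The compounds shown leave open whether any benzyl group on the shared core gives a readable number in this assay at all.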